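A few compounds are considered here, and "the series" means these few. Any claim that something is new, unique, unknown or untested is made for them only; others in the source may bear on it.

Measured so far in a functional assay on NCI/ADR-RES cells (Homo sapiens) for inhibition, read by sulforhodamine B assay, with a stated time of 48 h, tested at 10 uM; on this read-out lower numbers stand for a stronger effect and higher numbers for a weaker effect at the one concentration tested:
- compound 1 `O=C(Nc1cccc(-n2cc(-c3ccncc3)c(-c3cc(O)cc(Cl)c3)n2)c1)Nc1ccc(Cl)c(Cl)c1`: compound 1 gives 12.8%
- compound 2 `COc1cc(Cl)cc(-c2nn(-c3cccc(NC(=O)Nc4ccc(Cl)c(C(F)(F)F)c4)c3)cc2-c2ccncc2)c1`: compound 2 gives 6.07%
- compound 3 `COc1cc(Cl)cc(-c2nn(-c3cccc(NC(=O)Nc4cc(C(F)(F)F)cc(C(F)(F)F)c4)c3)cc2-c2ccncc2)c1`: compound 3 gives 2.37%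

Compound 3 sits at the low end of the three numbers in this assay. The nearest number is that of compound 2, which lies within the scatter of compound 3, so the two cannot be told apart on this read-out. Compound 1 is the furthest away, and its gap to compound 3 lies beyond the scatter.

The next compound, compound 4 `COc1cc(Cl)cc(-c2nn(-c3cccc(NC(=O)Nc4cccc(C(F)(F)F)c4)c3)cc2-c2ccncc2)c1`, is not yet measured. It differs from compound 3 in one place:

hydrogen in place of trifluoromethyl on an aromatic carbon

Among the measured compounds shown here, no pair of measured compounds differs in one place, so no measured step gives a direct guide for this change. Compound 2 and compound 3 both carry a trifluoromethyl on the outer ring of the urea and both give low numbers; compound 4 keeps one trifluoromethyl. The step from compound 3 to compound 4 in this assay is expected to be small, most likely a rise toward a weaker effect, and it may not exceed the scatter: a number 4.6 percentage points higher from compound 3 to compound 4 (within the scatter). Compound 4 is therefore expected to give about 7%, with a range from 1% to 20%.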

Compound 4, a percentage reported as activity, at one concentration (the size of the read-out at that concentration, not a potency): 3.58%
Compound 4: middle estimate off by 3.4 percentage points, on the high side; the measured number falls inside the stated range.
By their numbers in this assay, from the lowest: compounds 3, 4, 2 and 1 (each within the scatter of the next, the first and the last beyond it).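

In this assay, among the compounds shown here, hydrogen in place of trifluoromethyl on an aromatic carbon gives a number 1.2 percentage points higher from compound 3 to compound 4 (within the scatter), the first one-place reading at this position, and it shows that the second trifluoromethyl is not needed to hold the low number on this read-out. Hydrogen in place of chloro on an aromatic carbon, a separate place on the same ring, gives a number 2.5 percentage points lower from compound 2 to compound 4 (within the scatter), so neither replacement separates from hydrogen here, and compound 4 , with one trifluoromethyl as its only substituent on that ring, cannot be told apart from compound 2 or compound 3 in this assay. No measurement at hand accounts for the size of either step.

From the compounds shown here alone, it remains open whether the remaining trifluoromethyl matters, which a step to hydrogen at that carbon would read directly, and whether an amine or a carboxylic acid at the same place would keep the number as low. With all three compounds reading low at a single concentration, any differences in potency among them also remain unresolved.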